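The source may hold more compounds than are shown below. What is called first, only, known or untested is meant among the compounds shown, and "the series" means these compounds.

In an ADME assay on Caco-2 cells (Homo sapiens) for permeability, in the apical to basolateral direction (on this read-out lower numbers stand for lower permeability and higher numbers for higher permeability), the three measured compounds stand as follows:

Compound 1 `Cn1cncc1CN1CC(N(CC2CCN(C(=O)CNC(=O)OC(C)(C)C)CC2)S(=O)(=O)c2ccccn2)Cc2cc(C#N)ccc21`: 0.5 10^-6 cm/s
Compound 2 `CCCC(=O)N1CCC(CN(C2Cc3cc(C#N)ccc3N(Cc3cncn3C)C2)S(=O)(=O)c2ccccn2)CC1`: 0.5 10^-6 cm/s
Compound 3 `Cn1cncc1CN1CC(N(CC2CCN(C(=O)c3ccco3)CC2)S(=O)(=O)c2ccccn2)Cc2cc(C#N)ccc21`: 0.5 10^-6 cm/s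

Compound 3 is level with compounds 1 and 2 at the digits given; its nearest neighbour is compound 1 and its furthest compound 2, and neither gap goes beyond the scatter. All three compounds share the same core and differ only in the group on one carbonyl carbon whose other neighbour is an amide-type nitrogen in a ring.

Compound 4 `CC(C)OC(=O)N1CCC(CN(C2Cc3cc(C#N)ccc3N(Cc3cncn3C)C2)S(=O)(=O)c2ccccn2)CC1` changes that same position once more: isopropoxy in place of furan-2-yl on a carbonyl carbon

Among the measured compounds shown here, three measured steps bear on this, all of them swaps at the same carbonyl carbon: no change at the digits printed from compound 1 to compound 2 (within the scatter), no change at the digits printed from compound 1 to compound 3 (within the scatter) and no change at the digits printed from compound 2 to compound 3 (within the scatter). Each of them left this assay unchanged within the scatter, whether the group was a chain, a carbamate-bearing chain or a five-membered aromatic ring. The step from compound 3 to compound 4 is therefore expected to be no change at the digits printed from compound 3 to compound 4 (within the scatter), that is, nothing beyond the scatter. Compound 4 is estimated at 0.5 10^-6 cm/s, with a range from 0.25 10^-6 cm/s to 1 10^-6 cm/s.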

Compound 4, apparent permeability: 1 10^-6 cm/s
Compound 4: the middle estimate sits 2.0-fold (0.30 log units) below what was measured; the measured number falls inside the stated range.
By their numbers in this assay, from the lowest: compounds 1, 2, 3 and 4 (each within the scatter of the next).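

In this assay, isopropoxy is the first group shown on this carbonyl carbon that is attached through oxygen rather than carbon. Swapping it in gives a 2.0-fold higher number from compound 3 to compound 4 (0.30 log units; within the scatter) in place of furan-2-yl, a 2.0-fold higher number from compound 2 to compound 4 (0.30 log units; within the scatter) in place of propyl and a 2.0-fold higher number from compound 1 to compound 4 (0.30 log units; within the scatter) in place of ((tert-butoxycarbonyl)amino)methyl. So an aromatic ring, chains and now an oxygen-linked group all stay within the scatter of one another in this assay, and nothing shown here gives a reason for these numbers.

Still open, on these data alone, is whether a group carrying a free amine or a carboxylic acid on this carbonyl carbon would move the number beyond the scatter. Also open, as far as these compounds go, is whether any change away from this position, such as replacing the nitrile on the shared core, would do so.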